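A few compounds are considered here, and "the series" means these few. Any claim that something is new, unique, unknown or untested is made for them only; others in the source may bear on it.

Three compounds that differ only in one group on an aromatic ring of a shared core have been measured in a functional assay on CCRF-CEM cells (Homo sapiens) for antiproliferative activity, read by MTT assay, with a stated time of 96 h; a lower number here means a stronger inhibitor, a higher number a weaker inhibitor. Compound 1 `O=C1C2=C(C(=O)c3ncccc31)C1(CS2)NC(=O)N(c2ccc(Cl)cc2)C1=O`, with chloro, gives 10 nM. Compound 2 `CCN(CC)c1ccc(N2C(=O)NC3(CSC4=C3C(=O)c3ncccc3C4=O)C2=O)cc1`, with diethylamino, gives 20 nM. Compound 3 `CCCCc1ccc(N2C(=O)NC3(CSC4=C3C(=O)c3ncccc3C4=O)C2=O)cc1`, with butyl, gives 150 nM, the highest number of the three and so the weakest inhibitor here.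

Compound 4 `CC(C)(C)c1ccc(N2C(=O)NC3(CSC4=C3C(=O)c3ncccc3C4=O)C2=O)cc1` changes only that chain: tert-butyl in place of butyl on an aromatic carbon. It has tert-butyl in place of butyl, the same atoms joined differently.

Among the measured compounds shown here, no measured step makes this exact swap, so the evidence is indirect. Replacing chloro with butyl gave a 15-fold higher number from compound 1 to compound 3 (1.18 log units; beyond the scatter), and replacing diethylamino with butyl gave a 7.5-fold higher number from compound 2 to compound 3 (0.88 log units; beyond the scatter), while a 2.0-fold higher number from compound 1 to compound 2 (0.30 log units; within the scatter) shows the other two groups level. Changes at this place can therefore matter a great deal, and compound 3 at 150 nM sits at the weak end, with more room to fall than to rise. A modest fall is expected, though a result within the scatter would be no surprise.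

The expected step is a 2.1-fold lower number from compound 3 to compound 4 (0.33 log units; beyond the scatter). For compound 4 the estimated value is 70 nM, with an expected range of 20 nM to 220 nM.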

Compound 4, half-maximal inhibitory concentration: 200 nM
Beside the measured number, compound 4's estimate is 2.9-fold (0.46 log units) below it, and the stated range covers the measured number.
By their numbers in this assay, from the lowest: compounds 1 and 2 (each within the scatter of the next); then compounds 3 and 4 (each within the scatter of the next).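

In this assay, tert-butyl in place of butyl gives a 1.3-fold higher number from compound 3 to compound 4 (0.12 log units; within the scatter), so joining the same atoms differently at this place leaves the two compounds level. Tert-butyl in place of diethylamino gives a 10-fold higher number from compound 2 to compound 4 (1.00 log units; beyond the scatter), and tert-butyl in place of chloro gives a 20-fold higher number from compound 1 to compound 4 (1.30 log units; beyond the scatter), which places butyl and tert-butyl together in a group apart from chloro and diethylamino, with no compound here going against that split. Nothing available here explains why the compounds divide this way.

As far as these compounds go, whether the split extends beyond these four compounds remains open, since a shorter chain such as methyl or a longer chain such as octyl could fall on either side. From the compounds shown here alone, it is equally open where a primary amine or a carboxylic acid at this place would fall.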